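From tert-Butoxy to 3-Carboxypropyl in a P2Y6 Antagonist Series

A few compounds are considered here, and "the series" means these few. Any claim that something is new, unique, unknown or untested is made for them only; others in the source may bear on it.

Three compounds share one core and differ only in the group attached to a triple-bonded carbon: compound 1 `CC(C)(C)OC(=O)NCC#Cc1ccc2c(c1)C=C([N+](=O)[O-])C(C(F)(F)F)O2`, compound 2 `C[Si](C)(C)C#Cc1ccc2c(c1)C=C([N+](=O)[O-])C(C(F)(F)F)O2` and compound 3 `O=C(O)c1ccc(C#Cc2ccc3c(c2)C=C([N+](=O)[O-])C(C(F)(F)F)O3)cc1`. In a functional assay on 1321N1 cells for antagonist activity at P2Y purinoceptor 6 (Homo sapiens), read by fluorescence and calcium flux (a higher number here means a weaker inhibitor, a lower number a stronger inhibitor), compound 1 gives 1200 nM, compound 2 gives 785 nM and compound 3 gives 1090 nM. Compound 1 carries the highest of the three numbers, yet every step away from it stays within the scatter: a 1.5-fold lower number from compound 1 to compound 2 (0.18 log units; within the scatter) and a 1.1-fold lower number from compound 1 to compound 3 (0.04 log units; within the scatter), as does a 1.4-fold higher number from compound 2 to compound 3 (0.14 log units; within the scatter).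

Compound 4 `O=C(O)CCCC(=O)NCC#Cc1ccc2c(c1)C=C([N+](=O)[O-])C(C(F)(F)F)O2` keeps the core and the amide-type nitrogen of compound 1 and changes the other side of the carbonyl: 3-carboxypropyl in place of tert-butoxy on a carbonyl carbon. Within the data shown here, no measured step touches this exact position, so the guidance comes only from the three exchanges at the triple-bonded carbon, which all fall within the scatter even when a 4-carboxyphenyl enters, as in compound 3 with 1090 nM. The expectation for compound 4 is therefore a step no larger than the scatter, a 1.1-fold lower number from compound 1 to compound 4 (0.04 log units; within the scatter). Compound 4 is estimated at 1100 nM, with a range from 500 nM to 2500 nM.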

Compound 4, half-maximal inhibitory concentration: 69100 nM
Compound 4: middle estimate off by 63-fold (1.80 log units), on the low side; measured number above the stated range.
By their numbers in this assay, from the lowest: compounds 2, 3 and 1 (each within the scatter of the next); then compound 4.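

Putting 3-carboxypropyl in place of tert-butoxy on the carbonyl carbon gives a 58-fold higher number from compound 1 to compound 4 (1.76 log units; beyond the scatter), so in this assay this position is far from indifferent to the group it carries. The earlier exchanges on the triple-bonded carbon all stayed within the scatter, even the one that brought in a carboxylic acid as 4-carboxyphenyl, a 1.1-fold lower number from compound 1 to compound 3 (0.04 log units; within the scatter), and that tolerance does not carry over to this site. Nothing available here explains why the number rises so far.

Going by these compounds, it remains open whether the rise follows from the carboxylic acid at the end of the chain or simply from losing tert-butoxy. A plain propyl group, a methyl ester or an amine at the chain end, on the same carbonyl carbon, would tell these two readings apart.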